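From Methyl to Methoxy on the Shared Core

The compounds below may be only part of what the source reports. "The series", "measured", "known", "first", "only" and "open" are said of these compounds alone.

Compound 1 `COc1ccccc1-n1cc(CN2C(=O)C[C@@H]3CC[C@@]2(C)C3(C)C)nn1`: 280 nM
Compound 2 `CC1(C)[C@H]2CC[C@]1(C)N(Cc1cn(-c3ccc(Br)cc3)nn1)C(=O)C2`: 450 nM
Compound 3 `Cc1ccc(-n2cc(CN3C(=O)C[C@@H]4CC[C@@]3(C)C4(C)C)nn2)cc1`: 390 nM

These three values all come from a functional assay on SGC-7901 cells (Homo sapiens) for inhibition, read by MTT assay, with a stated time of 24 h; on this read-out higher numbers stand for weaker inhibition and lower numbers for stronger inhibition. Compound 3 stands among the others with its value inside the scatter of both, so the three cannot be ranked on these numbers. Compound 4 `COc1ccc(-n2cc(CN3C(=O)C[C@@H]4CC[C@@]3(C)C4(C)C)nn2)cc1` has not yet been measured. It keeps the shared core and has methoxy in place of methyl on an aromatic carbon, para to a large group: methoxy in place of methyl on an aromatic carbon.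

Among the measured compounds shown here, no measured pair makes exactly this exchange, so the evidence is indirect. The closest is the swap of bromo for methyl on an aromatic carbon, which gave a 1.2-fold lower number from compound 2 to compound 3 (0.06 log units; within the scatter). Putting 4-methylphenyl in place of 2-methoxyphenyl gave a 1.4-fold higher number from compound 1 to compound 3 (0.14 log units; within the scatter), and putting 4-bromophenyl in its place gave a 1.6-fold higher number from compound 1 to compound 2 (0.21 log units; within the scatter). None of these three steps goes beyond the scatter in this assay, so no step beyond the scatter is expected here, and no direction can be argued. The expected step is a 1.1-fold lower number from compound 3 to compound 4 (0.03 log units; within the scatter). For compound 4 the estimated value is 360 nM, with an expected range from 180 nM to 720 nM.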

Compound 4, half-maximal inhibitory concentration: 480 nM
Beside the measured number, compound 4's estimate is 1.3-fold (0.12 log units) below it; the measured number falls inside the stated range.
By their numbers in this assay, from the lowest: compounds 1, 3, 2 and 4 (each within the scatter of the next).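

In this assay, methoxy in place of methyl on the aromatic carbon para to a large group gave a 1.2-fold higher number from compound 3 to compound 4 (0.09 log units; within the scatter) and methoxy in place of bromo at that same place gave a 1.1-fold higher number from compound 2 to compound 4 (0.03 log units; within the scatter) so methyl, bromo and methoxy there now all lie within the scatter of one another, and an oxygen-bearing group at this place separates from neither of the other two. The new compound also gives the first view of the same methoxy group in two placements on the phenyl ring: 4-methoxyphenyl in place of 2-methoxyphenyl on the aromatic nitrogen gave a 1.7-fold higher number from compound 1 to compound 4 (0.23 log units; within the scatter) and even that change does not leave the scatter. No measurement of any other kind is at hand that bears on these numbers.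

On these data alone, what remains open is whether an amine or a carboxylic acid on that aromatic carbon, or a longer chain such as butoxy, would stay within the scatter of these values as well. Every compound shown also carries a substituted phenyl on the aromatic nitrogen, so the compounds leave open how an unsubstituted phenyl would compare with them.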